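This account rests on a few compounds, and the source may have more. Where it says the series, first, only, none or still open, it means among the compounds named here.

Working notes on the series, varied on an amide-type nitrogen of the core of compound 1 `O=C(NC1CCC(O)CC1)N1CCC(c2nc(-c3ccc4ccccc4n3)no2)CC1`. In a functional assay on Shh Light II cells (Mus musculus) for inhibition, read by a luciferase reporter (on this read-out higher numbers stand for weaker inhibition and lower numbers for stronger inhibition), compound 1 gives 2700 nM, compound 2 `CC(=O)N1CCC(NC(=O)N2CCC(c3nc(-c4ccc5ccccc5n4)no3)CC2)CC1` gives 500 nM and compound 3 `COc1ccccc1NC(=O)N1CCC(c2nc(-c3ccc4ccccc4n3)no2)CC1` gives 410 nM. Compound 3 therefore stands level with compound 2, as a 1.2-fold lower number from compound 2 to compound 3 (0.09 log units; within the scatter) shows, and well apart from compound 1, as a 6.6-fold lower number from compound 1 to compound 3 (0.82 log units; beyond the scatter) shows.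

Next is compound 4 `O=C(NC1CCCCC1)N1CCC(c2nc(-c3ccc4ccccc4n3)no2)CC1`, which carries cyclohexyl in place of 2-methoxyphenyl on an amide-type nitrogen, that is, cyclohexyl in place of 2-methoxyphenyl on an amide-type nitrogen. For the measured compounds named here, two measured steps bear on this change and pull in different directions. Compound 2, with 1-acetylpiperidin-4-yl, shows that a non-aromatic ring can match 2-methoxyphenyl, since a 1.2-fold lower number from compound 2 to compound 3 (0.09 log units; within the scatter). Going by the values given here, compound 1, the only measured compound with a substituted cyclohexyl, goes against this with a 5.4-fold lower number from compound 1 to compound 2 (0.73 log units; beyond the scatter) and a 6.6-fold lower number from compound 1 to compound 3 (0.82 log units; beyond the scatter). In this assay, a small move towards a higher number is therefore expected, probably not beyond the scatter. The expected change is a 1.7-fold higher number from compound 3 to compound 4 (0.23 log units; within the scatter). For compound 4 the estimated value is 700 nM, with an expected range of 230 nM to 2100 nM.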

Compound 4, half-maximal inhibitory concentration: 57 nM
The estimate for compound 4 lay 12-fold (1.09 log units) above the measured number; measured number outside the range, below it.
By their numbers in this assay, from the lowest: compound 4; then compounds 3 and 2 (each within the scatter of the next); then compound 1.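

In this assay, for the compounds shown here, cyclohexyl on the amide-type nitrogen is the first group here to stand clearly apart from 2-methoxyphenyl (a 7.2-fold lower number from compound 3 to compound 4 (0.86 log units; beyond the scatter)) and from 1-acetylpiperidin-4-yl (an 8.8-fold lower number from compound 2 to compound 4 (0.94 log units; beyond the scatter)), so a non-aromatic carbon ring at this position is more than a match for the aromatic one. The largest step in the series is the loss of a single hydroxy from the saturated ring (a 47-fold lower number from compound 1 to compound 4 (1.68 log units; beyond the scatter)), which shows that the high number of compound 1 goes with the hydroxy and not with the cyclohexyl ring as such. No measurement in hand accounts for either finding.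

Still open, going by these compounds, is whether the gain depends on ring size, which cyclopentyl or cycloheptyl on the same nitrogen would test. Also open, on these data alone, is whether a methyl, methoxy or fluorine on the cyclohexyl ring would cost as much as the hydroxy.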